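This account rests on a few compounds, and the source may have more. Where it says the series, first, only, none or still open, it means among the compounds named here.

For the measured compounds named here, in a functional assay on KB cells (Homo sapiens) for inhibition, read by MTT assay, with a stated time of 24 h, tested at 100 ug/mL (on this read-out lower numbers stand for less inhibition of growth and higher numbers for more inhibition of growth at the one concentration tested), compound 1 `CC(=O)SCCC(CCCCC(=O)O)SC(C)=O` gives 8.03%, the lower of the two numbers so far. Compound 2 `O=C(O)CCCCC(CCSC(=O)c1ccccc1)SC(=O)c1ccccc1` gives 89.8%, which lies far above compound 1, beyond the scatter. Compound 3 `CC(=O)SCCC(CCCCC(=O)Nc1ccccc1)SC(C)=O` keeps the core of compound 1 but has anilino in place of hydroxy on a carbonyl carbon. Going by the values given here, no measured pair shows this change, so the expectation is loose. In this assay, a moderate rise beyond the scatter is expected, an estimated step of a number 27 percentage points higher from compound 1 to compound 3 (beyond the scatter). The estimate for compound 3 is 35%, within a range from 10% to 70%.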

Compound 3, percent growth inhibition at one concentration: 23%
The estimate for compound 3 lay 12 percentage points above the measured number, within the range that was stated.
By their numbers in this assay, from the lowest: compound 1; then compound 3; then compound 2.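

In this assay, for the compounds shown here, putting anilino in place of hydroxy on a carbonyl carbon gives a modest step, a number 15 percentage points higher from compound 1 to compound 3 (beyond the scatter), the first reading of a change at this place. The carbonyl carbon therefore accepts a much larger group with an aromatic ring, with the core of compound 1 kept and no loss of growth inhibition. No available evidence explains this rise.

The compounds shown leave open whether the aromatic ring matters or the amide alone is enough. A methylamino group in the same place would separate the two.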